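A few compounds are considered here, and "the series" means these few. Any claim that something is new, unique, unknown or untested is made for them only; others in the source may bear on it.

Three compounds built on the same core, an aryl urea carried on the shared scaffold, have been measured so far. Compound 1 `COc1ccc(NC(=O)Nc2cccc(CNc3nccnc3Cl)c2)cc1` gives 9240 nM in a functional assay on MGC-803 cells (Homo sapiens) for antiproliferative activity, read by MTT assay, with a stated time of 48 h; a lower number here means a stronger inhibitor, a higher number a weaker inhibitor. Compound 2 `COc1ccccc1NC(=O)Nc1cccc(CNc2nccnc2Cl)c1` gives 12200 nM in the same assay, and compound 3 `Cc1cccc(NC(=O)Nc2cccc(CNc3nccnc3Cl)c2)c1` gives 14600 nM. The steps between them are small: a 1.3-fold higher number from compound 1 to compound 2 (0.12 log units; within the scatter), a 1.6-fold higher number from compound 1 to compound 3 (0.20 log units; within the scatter) and a 1.2-fold higher number from compound 2 to compound 3 (0.08 log units; within the scatter). Compound 1 thus shows the lowest of the three numbers, but both other compounds sit within the scatter of it, so no order among the three can be claimed.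

Compound 4 `CS(=O)(=O)c1ccc(NC(=O)Nc2cccc(CNc3nccnc3Cl)c2)cc1` is the next compound. It differs from compound 1 in one place: methylsulfonyl in place of methoxy on an aromatic carbon. Among the measured compounds shown here, no measured step introduces a methylsulfonyl; the three steps in hand all exchange one substituted aryl group for another on the amide-type nitrogen, and each stays within the scatter. For the measured compounds named here, they therefore offer no precedent for a move of this kind, and the expectation is that compound 4 falls near compound 1 with a wide range of uncertainty. The step from compound 1 to compound 4 is expected to be a 1.0-fold higher number from compound 1 to compound 4 (0.01 log units; within the scatter). Compound 4 is estimated to give about 9500 nM, with a range from 3000 nM to 30000 nM.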

Compound 4, half-maximal inhibitory concentration: 12300 nM
The estimate for compound 4 lay 1.3-fold (0.11 log units) below the measured number, within the range that was stated.
By their numbers in this assay, from the lowest: compounds 1, 2, 4 and 3 (each within the scatter of the next).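

In this assay, among the compounds shown here, the first change at this position, on an aromatic carbon para to a large group, gives a 1.3-fold higher number from compound 1 to compound 4 (0.12 log units; within the scatter). Until now, the steps had exchanged one substituted aryl group for another on the amide-type nitrogen; this one keeps the aryl group and alters only its substituent, with methylsulfonyl in place of methoxy, taking the heavy atoms from 2 to 4 and the hydrogen-bond acceptors from 1 to 2, and even so the number stays within the scatter of compound 1. No measurement is available that bears on why these two groups cannot be told apart in this assay.

The compounds shown leave open whether any group at this position can move the number beyond the scatter, for instance an amine, a carboxylic acid or a trifluoromethyl, each of which would test the position with a different kind of substituent. They also leave open whether methylsulfonyl would read the same when carried at another carbon of this ring, as the methoxy group does in compound 2.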